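Amino-methoxyphenyl isomers on the sulfonyl chain carbon

The source may report more compounds than this note shows. Statements on the series, on what has been measured and on what is new or still open speak of the compounds shown alone.

Within the data shown here, in a functional assay on K562 cells (Homo sapiens) for cytotoxicity, read by trypan blue exclusion, with a stated time of 96 h (a lower number here means a stronger inhibitor, a higher number a weaker inhibitor), compound 3 (`COc1cc(OC)c(/C=C/S(=O)(=O)Cc2ccc(OC)c(N)c2)c(OC)c1`) gives 2.5 nM, the lowest of the three numbers so far. Compound 2 (`COc1ccc(CS(=O)(=O)/C=C/c2c(OC)cc(OC)cc2OC)c(N)c1`) follows at 25 nM, and compound 1 (`COc1cc(OC)c(/C=C/S(=O)(=O)Cc2ccc(F)c(N)c2)c(OC)c1`) stands highest at 2500 nM.

Compound 4 (`COc1cc(OC)c(/C=C/S(=O)(=O)Cc2cc(N)ccc2OC)c(OC)c1`) has the same atoms as compound 3, joined differently: 5-amino-2-methoxyphenyl in place of 3-amino-4-methoxyphenyl on a saturated chain carbon bound to a sulfonyl sulfur. This places 5-amino-2-methoxyphenyl in place of 3-amino-4-methoxyphenyl on a saturated chain carbon bound to a sulfonyl sulfur.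

Among the measured compounds shown here, the closest precedent is a 10-fold lower number from compound 2 to compound 3 (1.00 log units; beyond the scatter), a modest step that also exchanges one amino-methoxyphenyl isomer for another at that place. It shows that such an exchange alone can move the number beyond the scatter. The larger steps, a 1000-fold lower number from compound 1 to compound 3 (3.00 log units; beyond the scatter) and a 100-fold lower number from compound 1 to compound 2 (2.00 log units; beyond the scatter), both start from the fluoro compound and show how far a change in this group can reach, but neither is an exchange between isomers.

For the measured compounds named here, nothing measured so far shows an isomer with a lower number than compound 3, although two isomers are a thin basis for the direction. A move toward a higher number, modest in size, is therefore expected in this assay. The expected change is a 20-fold higher number from compound 3 to compound 4 (1.30 log units; beyond the scatter). Compound 4 is estimated at 50 nM, with an expected range of 6 nM to 500 nM.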

Compound 4, half-maximal inhibitory concentration: 7500 nM
The estimate for compound 4 lay 150-fold (2.18 log units) below the measured number; the measured number lies above the stated range.
By their numbers in this assay, from the lowest: compound 3; then compound 2; then compound 1; then compound 4.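

In this assay, moving the two substituents around the phenyl ring at this place can carry far more than the earlier isomer pair suggested: 5-amino-2-methoxyphenyl in place of 3-amino-4-methoxyphenyl gives a 3000-fold higher number from compound 3 to compound 4 (3.48 log units; beyond the scatter) and makes the largest step in the series. The same group in place of 2-amino-4-methoxyphenyl gives a 300-fold higher number from compound 2 to compound 4 (2.48 log units; beyond the scatter) as well, so compound 4 stands well apart from both other amino-methoxyphenyl isomers. Its comparison with the fluoro compound, a 3.0-fold higher number from compound 1 to compound 4 (0.48 log units; beyond the scatter) in this assay, shows that an amino-methoxyphenyl group does not by itself secure a low number: compound 2 and compound 3 lie on the low side of compound 1, and compound 4 goes against that pattern. Nothing on hand accounts for the size of these steps.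

The three isomers do not separate the contribution of the amino group's place from that of the methoxy group's place, since compound 4 differs from compound 3 in both. Going by these compounds, it also remains open whether the low number of compound 3 depends on the amino group itself, as a hydroxy group or a dimethylamino group at that place would test.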